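Notes on the side group of compound 2

A few compounds are considered here, and "the series" means these few. Any claim that something is new, unique, unknown or untested is made for them only; others in the source may bear on it.

- compound 1 `O=C1CNC(=O)N1C[C@H]1CN(c2ccc(-n3cc(-c4ccccn4)cn3)c(F)c2)C(=O)O1`: 1.25
- compound 2 `O=C1O[C@@H](Cn2ccnc2)CN1c1ccc(-n2cc(-c3ccccn3)cn2)c(F)c1`: 1.73

In a physicochemical assay for lipophilicity, read by HPLC, measured as octanol-water partition (on this read-out lower numbers stand for lower lipophilicity and higher numbers for higher lipophilicity), compound 2 at 1.73 stands highest of the two measured, with compound 1 at 1.25 lower. Compound 3 `CN(C)S(=O)(=O)NC[C@H]1CN(c2ccc(-n3cc(-c4ccccn4)cn3)c(F)c2)C(=O)O1` takes (dimethylsulfamoyl)amino in place of 1H-imidazol-1-yl on a saturated chain carbon bound to a saturated ring carbon. Going by the values given here, the one measured step at this place, a number 0.48 log units higher from compound 1 to compound 2 (beyond the scatter) (modest), has 1H-imidazol-1-yl entering rather than leaving and is only a loose guide. A small downward step, possibly within the scatter, is expected in this assay as the estimate a number 0.23 log units lower from compound 2 to compound 3 (within the scatter) shows. The estimate for compound 3 is 1.5 with an expected range from 1.1 to 1.95 as a working figure.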

Compound 3, partition coefficient: 1.38
The estimate for compound 3 lay 0.12 log units above the measured number; low and high end bracket the measured number.
By their numbers in this assay, from the lowest: compounds 1 and 3 (each within the scatter of the next); then compound 2.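

In this assay, the side group on a saturated chain carbon bound to a saturated ring carbon now has a second measured exchange away from 1H-imidazol-1-yl, which reads a number 0.35 log units lower from compound 2 to compound 3 (beyond the scatter). Ring-free (dimethylsulfamoyl)amino and ring-bearing 2,5-dioxoimidazolidin-1-yl are not separated here, the step reading a number 0.13 log units higher from compound 1 to compound 3 (within the scatter). Nothing measured explains why compound 2 stands apart from both.

As far as these compounds go, whether a simple amine, a carboxylic acid or a longer chain at this place would fall with compound 1 and compound 3, or with compound 2, remains open.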